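Chloro position on the amide aryl ring in KB cells

The compounds below may be only part of what the source reports. "The series", "measured", "known", "first", "only" and "open" are said of these compounds alone.

Measured compounds:
compound 1, `CC(=O)SCCC(CCCCC(=O)Nc1ccccc1Cl)SC(C)=O`, gives 7.05% in a functional assay on KB cells (Homo sapiens) for inhibition, read by MTT assay, with a stated time of 24 h, tested at 0.1 ug/mL; on this read-out lower numbers stand for less inhibition of growth and higher numbers for more inhibition of growth at the one concentration tested
compound 2, `CC(=O)SCCC(CCCCC(=O)Nc1cccc(Cl)c1)SC(C)=O`, gives 5.72% in this assay
compound 3, `O=C(CCCCC(CCSC(=O)c1ccccc1)SC(=O)c1ccccc1)Nc1ccccc1Cl`, gives 3.62% in this assay

Compound 2 differs from compound 1 by 3-chlorophenyl in place of 2-chlorophenyl on an amide-type nitrogen, and in this assay this change gave a number 1.3 percentage points lower from compound 1 to compound 2 (within the scatter). Compound 3 is built on a different core; the difference between the two cores is not broken down here, and its value lies within the scatter of compound 1 and compound 2. Compound 4, `O=C(CCCCC(CCSC(=O)c1ccccc1)SC(=O)c1ccccc1)Nc1cccc(Cl)c1`, has not been measured. It differs from compound 3 by 3-chlorophenyl in place of 2-chlorophenyl on an amide-type nitrogen, the same change as from compound 1 to compound 2. Because the earlier step, a number 1.3 percentage points lower from compound 1 to compound 2 (within the scatter), was small, a similarly small step is expected, estimated as a number 1.1 percentage points lower from compound 3 to compound 4 (within the scatter). Compound 4 is therefore estimated at 2.5% in this assay, with a likely range from -6% to 11%.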

Compound 4, percent growth inhibition at one concentration: 10.7%
Compound 4: the middle estimate sits 8.2 percentage points below what was measured, within the range that was stated.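

Putting 3-chlorophenyl in place of 2-chlorophenyl on the amide-type nitrogen gave a number 7.1 percentage points higher from compound 3 to compound 4 (within the scatter) in this assay. Set beside the earlier step, the two cores show no real difference in how they respond to this change: the same change on two cores in this assay, a number 1.3 percentage points lower (within the scatter) from compound 1 to compound 2 and a number 7.1 percentage points higher (within the scatter) from compound 3 to compound 4, 8.4 percentage points apart, within the scatter of two such steps. This agrees with the change carrying over from one core to the other, but it does not show that the change has any real effect on either core, and a small difference between the cores could go unseen within the scatter.

The compounds shown leave open whether a free thiol in place of the acetyl or benzoyl thioesters, or a methoxy group in place of the chlorine, would alter growth inhibition. Also open, as far as these compounds go, is what happens at concentrations other than the single one tested.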